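Swapping the azetidine acyl group for an ethyl group

The source may hold more compounds than are shown below. What is called first, only, known or untested is meant among the compounds shown, and "the series" means these compounds.

Of the compounds shown here, three carrying the same bis-sulfonyl benzene core have been measured in a functional assay on BXPC-3 cells (Homo sapiens) for inhibition, read by MTT assay, with a stated time of 7 days; a lower number here means a stronger inhibitor, a higher number a weaker inhibitor. Compound 1 `CCOC(=O)C1CCN(S(=O)(=O)c2ccc(S(=O)(=O)N(CC)CC)cc2)CC1` gives 23100 nM. Compound 2 `CCN(CC)S(=O)(=O)c1ccc(S(=O)(=O)N2CCC[C@@H](C(=O)N(C)C(C)C)C2)cc1` gives 7700 nM. Going by the values given here, compound 3 `CCN(CC)S(=O)(=O)c1ccc(S(=O)(=O)N2CCC[C@@H](C(=O)NC3CN(C(=O)C4CC4)C3)C2)cc1` gives 18500 nM, the second highest of the three numbers: it sits within the scatter of compound 1, and it differs from compound 2 by a 2.4-fold higher number from compound 2 to compound 3 (0.38 log units; beyond the scatter), the only measured step in the set.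

Compound 4 `CCN1CC(NC(=O)[C@@H]2CCCN(S(=O)(=O)c3ccc(S(=O)(=O)N(CC)CC)cc3)C2)C1` is not yet measured. Its difference from compound 3 is ethyl in place of cyclopropylcarbonyl on an amine nitrogen in a ring. Among the compounds with values here, no measured step touches the amine nitrogen of the azetidine ring; the one step on record changed the amide substituent itself and was modest. On that basis no step beyond the scatter is expected from compound 3 to compound 4, and the number for compound 4 is estimated at 18000 nM, from 7000 nM to 45000 nM, which corresponds to an expected step of a 1.0-fold lower number from compound 3 to compound 4 (0.01 log units; within the scatter).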

Compound 4, half-maximal inhibitory concentration: > 30000 nM
Compound 4: a limit, no number; the forecaster's own chance of this, stated with the estimate: 10%; middle value at least 1.6-fold (0.22 log units) away from the limit.
By their numbers in this assay, from the lowest: compound 2; then compounds 3 and 1 (each within the scatter of the next). At a limit, above all of these: compound 4.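

In this assay compound 4 gives a limit and not a number: the limit of > 30000 nM in this assay, at which 1 of the 4 values shown sits.

Going by these compounds alone, this is the first reading of a change on the amine nitrogen in the four-membered ring. Ethyl in place of cyclopropylcarbonyl there gives an at least 1.6-fold higher number from compound 3 to compound 4 (0.20 log units; that floor lies within the scatter), so the floor of this step does not clear the scatter and no loss can be claimed, although no gain appears either. With the ethyl group, the change on the carbonyl carbon gives an at least 3.8-fold higher number from compound 2 to compound 4 (0.59 log units; beyond the scatter), which points the same way as a 2.4-fold higher number from compound 2 to compound 3 (0.38 log units; beyond the scatter).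

The compounds shown leave open how far the number for compound 4 really lies from that of compound 3. They also leave open whether an acetyl group, a longer alkyl chain or the free amine on that nitrogen would give a number closer to that of compound 2.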